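Building Out the Amide Nitrogen of Compound 2

The source may report more compounds than this note shows. Statements on the series, on what has been measured and on what is new or still open speak of the compounds shown alone.

In an ADME assay on microsomes from liver (Rattus norvegicus) for metabolic stability, read by mass spectrometry, with a stated time of 10 min, tested at 0.5 uM (on this read-out higher numbers stand for a more stable compound and lower numbers for a less stable compound), compound 1 (`CNc1cc(Nc2cc(F)cc(F)c2OC)nn2c(C(=O)NCC(C)(C)CO)cnc12`) gives 34% and compound 2 (`CNc1cc(Nc2cc(C)cc(C)c2)nn2c(C(N)=O)cnc12`) gives 21%, the lower of the two numbers and beyond the scatter. Compound 3 (`CNc1cc(Nc2cc(C)cc(C)c2)nn2c(C(=O)NCC(C)(CO)CO)cnc12`) has 2,2-bis(hydroxymethyl)propyl in place of hydrogen on an amide-type nitrogen of compound 2 (2,2-bis(hydroxymethyl)propyl in place of hydrogen on an amide-type nitrogen). Among the compounds with values here, no measured pair isolates this change. A modest rise beyond the scatter is expected, resting only on compound 1, also substituted on its amide nitrogen, at 34%. The expected change is a number 12 percentage points higher from compound 2 to compound 3 (beyond the scatter). For compound 3 the expected value is 33%, within a range of 16% to 55%.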

Compound 3, percent of the compound remaining: 16%
Compound 3: middle estimate off by 17 percentage points, on the high side; measured number inside the range.
By their numbers in this assay, from the lowest: compounds 3 and 2 (each within the scatter of the next); then compound 1.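

In this assay, 2,2-bis(hydroxymethyl)propyl in place of hydrogen on the amide-type nitrogen gives a number 5 percentage points lower from compound 2 to compound 3 (within the scatter). Within the data shown here, this is the first pair that isolates the change, and it shows that this chain can replace the amide hydrogen with no difference that stands clear of the scatter. Nothing at hand offers an explanation for this result. From the compounds shown here alone, it remains open whether a shorter chain, an amine or a carboxylic acid on this nitrogen would leave the read-out as little moved. Compound 1 differs from compound 3 in more than one place, so it cannot settle this.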